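Shortening the tail: phenoxy for phenoxymethyl on the methylamide oxazole

This account rests on a few compounds, and the source may have more. Where it says the series, first, only, none or still open, it means among the compounds named here.

Measured so far:
- compound 1, `O=C(O)c1ccc(-c2cnc(C(=O)CCc3ccc(Oc4ccccc4)cc3)o2)nc1`: 33 nM
- compound 2, `CNC(=O)c1cnc(C(=O)CCc2ccc(COc3ccccc3)cc2)o1`: 3.6 nM

Both compounds were tested in an assay for inhibition of Fatty-acid amide hydrolase 1 (Rattus norvegicus); a lower number here means a stronger inhibitor, a higher number a weaker inhibitor. Compound 1 gives 33 nM, while compound 2 gives 3.6 nM. Of the two numbers, compound 2 has the lower one, and the gap to compound 1 lies beyond the scatter of repeated measurements. The two compounds differ in more than one place, so their values are simply two separate points rather than a measured step.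

The next compound, compound 3, `CNC(=O)c1cnc(C(=O)CCc2ccc(Oc3ccccc3)cc2)o1`, keeps the core and the methylamide of compound 2 and changes only the tail: phenoxy in place of phenoxymethyl on an aromatic carbon. The tail is thus one carbon shorter, with the same ring and the same single acceptor at its end. Compound 1 already carries this phenoxy tail and sits in the low double-digit range, so the tail itself is compatible with tight binding. The expected step of a 1.7-fold higher number from compound 2 to compound 3 (0.22 log units; within the scatter) is small, at most a mild weakening, and may fall within the scatter. For compound 3 the estimate in this assay is 6 nM, with a range from 1.5 nM to 25 nM.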

Compound 3, inhibition constant: 11 nM
For compound 3 the middle estimate is 1.8-fold (0.26 log units) below the measured one, within the range that was stated.
By their numbers in this assay, from the lowest: compound 2; then compound 3; then compound 1.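

In this assay the length of the tail counts on the methylamide compounds: phenoxy in place of phenoxymethyl, on an aromatic carbon para to a large group, gives a 3.1-fold higher number from compound 2 to compound 3 (0.49 log units; beyond the scatter), a modest change. Compound 3 also turns the earlier pair of separate points into a readable comparison, since with the phenoxy tail held constant, methylcarbamoyl in place of 5-carboxypyridin-2-yl gives a 3.0-fold lower number from compound 1 to compound 3 (0.48 log units; beyond the scatter), also modest, so the number responds to the group at this other end of the molecule too. Nothing measured here gives a cause for either step.

Whether a phenoxyethyl tail, one carbon longer than phenoxymethyl, would raise or lower the number remains open, so the two tails shown on the methylamide compounds do not yet define a best length. From the compounds shown here alone, it also remains open how a simple carboxylic acid or a primary amide would compare with methylcarbamoyl, and whether the tail change would have the same effect on a compound carrying 5-carboxypyridin-2-yl.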